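The compounds below may be only part of what the source reports. "The series", "measured", "known", "first", "only" and "open" are said of these compounds alone.

Three compounds have numbers in a functional assay on P388 cells (Mus musculus) for inhibition; on this read-out lower numbers stand for stronger inhibition and higher numbers for weaker inhibition. Compound 1 `O=C1/C(=C/c2ccccc2F)CCc2ccccc21` gives 21800 nM. Compound 2 `O=C1/C(=C/c2ccc(Cl)cc2Cl)CCc2ccccc21` gives 17200 nM, and compound 3 `O=C1/C(=C/c2ccccc2Br)CCCc2ccccc21` gives 19800 nM. Compound 1 has the highest of the three numbers, yet its gaps to compound 3 and to compound 2 both lie within the usual scatter of this assay, so the three cannot be told apart. Compound 4 `O=C1/C(=C/c2ccccc2Br)CCc2ccccc21` is not yet measured. It differs from compound 1 in one place: bromo in place of fluoro on an aromatic carbon. Among the measured compounds shown here, no measured pair shows this change alone, so the expected step of a 1.1-fold lower number from compound 1 to compound 4 (0.06 log units; within the scatter) is none beyond the scatter. Compound 4 is expected to give 19000 nM, with a range from 8000 nM to 45000 nM. This estimate also leans on compound 3, which carries bromo and gives 19800 nM.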

Compound 4, half-maximal inhibitory concentration: 19700 nM
The estimate for compound 4 lay 1.0-fold (0.02 log units) below the measured number; the range from low to high includes it.
By their numbers in this assay, from the lowest: compounds 2, 4, 3 and 1 (each within the scatter of the next).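

In this assay, bromo in place of fluoro on an aromatic carbon, ortho to a large group, gives a 1.1-fold lower number from compound 1 to compound 4 (0.04 log units; within the scatter) and so isolates this change for the first time among the compounds shown. At this position, the two halogens cannot be told apart on this read-out. No available evidence bears on this result. From the compounds shown here alone, whether a group other than a halogen, such as an amine or a carboxylic acid, would move the number at this position remains open. So does the effect of the same change at other positions on the ring.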